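The source may report more compounds than this note shows. Statements on the series, on what has been measured and on what is new or still open speak of the compounds shown alone.

Measured so far in an ADME assay on HT-29 cells (Homo sapiens) for cytotoxicity, read by MTT assay, with a stated time of 72 h; on this read-out lower numbers stand for stronger inhibition and higher numbers for weaker inhibition:
compound 1, `C=CC(=O)Nc1cc(Nc2ncc3ncn(-c4ccc(CC)cc4)c3n2)c(OC)cc1N(C)CCN(C)C`: 8180 nM
compound 2, `C=CC(=O)Nc1cc(Nc2ncc3ncn(-c4ccccc4Br)c3n2)c(OC)cc1N(C)CCN(C)C`: 16200 nM

Compound 2 stands at the upper end of the two numbers shown in this assay, yet the step of a 2.0-fold higher number from compound 1 to compound 2 (0.30 log units; within the scatter) lies within the scatter, so the two compounds are not separated by it. Compound 3, `C=CC(=O)Nc1cc(Nc2ncc3ncn(-c4ccc(F)c(Br)c4)c3n2)c(OC)cc1N(C)CCN(C)C`, differs from compound 2 in a single place: 3-bromo-4-fluorophenyl in place of 2-bromophenyl on an aromatic nitrogen. Within the data shown here, the only measured step that bears on this change is the earlier exchange of the aryl group on the same aromatic nitrogen, a 2.0-fold higher number from compound 1 to compound 2 (0.30 log units; within the scatter), which stayed within the scatter. With nothing beyond that to draw on, the account expects no step beyond the scatter in this assay for compound 3. The estimate for compound 3 in this assay is 12000 nM, with a range from 4000 nM to 40000 nM. That amounts to an expected 1.4-fold lower number from compound 2 to compound 3 (0.13 log units; within the scatter), within the scatter.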

Compound 3, half-maximal inhibitory concentration: 3640 nM
Beside the measured number, compound 3's estimate is 3.3-fold (0.52 log units) above it, and the stated range ends above it.
By their numbers in this assay, from the lowest: compound 3; then compounds 1 and 2 (each within the scatter of the next).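

Among these compounds, the aryl group on this aromatic nitrogen can shift the number in this assay beyond the scatter, which the only earlier step did not show: 3-bromo-4-fluorophenyl in place of 2-bromophenyl gives a 4.5-fold lower number from compound 2 to compound 3 (0.65 log units; beyond the scatter) and so separates two aryl groups that both carry bromine. The same group also stands apart from 4-ethylphenyl, with a 2.2-fold lower number from compound 1 to compound 3 (0.35 log units; beyond the scatter), so compound 3 has the lowest number of the three, although both steps are modest. Nothing on hand explains why this exchange lowers the number.

The compounds shown leave open how much of the step belongs to the bromine and how much to the fluorine of the 3-bromo-4-fluorophenyl group, as compound 3 brings in both together. Also open, on these data alone, is how a phenyl group carrying an amine or a carboxylic acid would compare on this nitrogen.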